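Methoxy in place of hydrogen: from compound 1 to compound 4

The source may report more compounds than this note shows. Statements on the series, on what has been measured and on what is new or still open speak of the compounds shown alone.

Compound 1 `O=[N+]([O-])c1cc(-c2nnn(Cc3ccccc3)n2)cc([N+](=O)[O-])c1` was tested in an ADME assay on CHO-K1 cells (Cricetulus griseus) for cytotoxicity, read by MTT assay, with a stated time of 24 h (a lower number here means a stronger inhibitor, a higher number a weaker inhibitor), where compound 1 gives 150000 nM, the lowest of the three numbers measured. Compound 2 `O=[N+]([O-])c1cc(-c2nnn(Cc3ccc(Cl)cc3)n2)cc([N+](=O)[O-])c1` gives 170000 nM and compound 3 `O=[N+]([O-])c1cc(-c2nnn(Cc3cccc(F)c3)n2)cc([N+](=O)[O-])c1` gives 315000 nM. The step of a 1.1-fold higher number from compound 1 to compound 2 (0.05 log units; within the scatter) lies within the scatter, while a 2.1-fold higher number from compound 1 to compound 3 (0.32 log units; beyond the scatter) is modest and beyond it; the comparison a 1.9-fold higher number from compound 2 to compound 3 (0.27 log units; within the scatter) stays within the scatter. Compound 4 `COc1ccc(Cn2nnc(-c3cc([N+](=O)[O-])cc([N+](=O)[O-])c3)n2)cc1` differs from compound 1 by methoxy in place of hydrogen on an aromatic carbon. Among the measured compounds shown here, the steps that bear on this change are the two substitutions on the same aromatic ring, from compound 1 to compound 2 and from compound 1 to compound 3, one of which stays within the scatter and one of which is a modest rise. A methoxy group is therefore expected to give a small upward step in this assay, possibly none beyond the scatter. Compound 4 is estimated at 200000 nM, within 100000 nM to 400000 nM, which means an expected step of a 1.3-fold higher number from compound 1 to compound 4 (0.12 log units; within the scatter).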

Compound 4, half-maximal inhibitory concentration: 96000 nM
Compound 4: middle estimate off by 2.1-fold (0.32 log units), on the high side, outside the stated range (below it).
By their numbers in this assay, from the lowest: compounds 4, 1, 2 and 3 (each within the scatter of the next, the first and the last beyond it).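

In this assay, methoxy on the aromatic carbon para to a large group leaves the parent's reading within the scatter, with a 1.6-fold lower number from compound 1 to compound 4 (0.19 log units; within the scatter), so this addition gives no change that can be told from repeat measurement. Replacing chloro with methoxy is likewise unresolved, at a 1.8-fold lower number from compound 2 to compound 4 (0.25 log units; within the scatter). Among the compounds shown here, the one new step beyond the scatter is modest, a 3.3-fold lower number from compound 3 to compound 4 (0.52 log units; beyond the scatter), but it changes both the group and its place on the ring, so it cannot be assigned to either alone.

No measurement shown here explains these steps. On these data alone, it remains open whether an amine or a carboxylic acid on the same aromatic carbon would shift the number beyond the scatter, and how methoxy would read at the ring place that fluoro holds in compound 3.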